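Ethylsulfonyl for pyrazolylcarbonyl on a second core

The source may report more compounds than this note shows. Statements on the series, on what has been measured and on what is new or still open speak of the compounds shown alone.

Measured so far in an ADME assay on microsomes from liver (Rattus norvegicus) for metabolic stability, read by LC-MS, using NADPH, with stated times of 10 min and 30 min; a lower number here means slower removal, a higher number faster removal of the compound:
compound 1, `Cn1cc(C(=O)N2CC3(C2)CN(c2cncc(N4C(=O)c5ccc(Cl)cc5C4(C)C)c2)C3)cn1`, gives 6.4 mL/min/kg
compound 2, `CCS(=O)(=O)N1CC(Oc2cncc(N3C(=O)c4ccc(Cl)cc4C3(C)C)c2)C1`, gives 5 mL/min/kg
compound 3, `Cn1cc(C(=O)N2CC(Oc3cncc(N4C(=O)c5ccc(Cl)cc5C4(C)C)c3)C2)cn1`, gives 6.4 mL/min/kg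

Compound 3 and compound 2 share a core and differ only in ethylsulfonyl in place of (1-methyl-1H-pyrazol-4-yl)carbonyl on an amine nitrogen in a ring; this step gives a 1.3-fold lower number from compound 3 to compound 2 (0.11 log units; within the scatter). Compound 1 carries a different core, and the difference between the two cores is not broken down here. Compound 1 is level with compound 3 at the digits given, and both lie within the scatter of compound 2, so no order among the three can be read from these numbers.

Compound 4, `CCS(=O)(=O)N1CC2(CN(c3cncc(N4C(=O)c5ccc(Cl)cc5C4(C)C)c3)C2)C1`, has not yet been measured. It differs from compound 1 by ethylsulfonyl in place of (1-methyl-1H-pyrazol-4-yl)carbonyl on an amine nitrogen in a ring. Within the data shown here, this is the same kind of change as the one from compound 3 to compound 2, not the same change: in compound 1 the amine nitrogen sits in a four-membered non-aromatic ring joined to another ring at one shared atom, in a system of two rings, whereas in compound 3 the ring atom bears a large group. Because the earlier step of a 1.3-fold lower number from compound 3 to compound 2 (0.11 log units; within the scatter) stayed within the scatter, the expected step is a 1.2-fold lower number from compound 1 to compound 4 (0.09 log units; within the scatter). Compound 4 is therefore estimated at 5.2 mL/min/kg, with an expected range from 3 mL/min/kg to 9.5 mL/min/kg.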

Compound 4, clearance: 0.87 mL/min/kg
Compound 4: middle estimate off by 6.0-fold (0.78 log units), on the high side; the whole stated range lies above it.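

In this assay, ethylsulfonyl in place of (1-methyl-1H-pyrazol-4-yl)carbonyl on an amine nitrogen in a ring gives a 7.4-fold lower number from compound 1 to compound 4 (0.87 log units; beyond the scatter). The same change therefore did not carry over at the same size from one core to the other: the same change on two cores in this assay, a 1.3-fold lower number (0.11 log units; within the scatter) from compound 3 to compound 2 and a 7.4-fold lower number (0.87 log units; beyond the scatter) from compound 1 to compound 4, 5.7-fold (0.76 log units) apart, beyond the scatter of two such steps. This shows that, across these two pairs, the size of the step depends on the core that carries it, but it does not show which feature of the cores is responsible, and two pairs set no rule for any further core.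

The compounds shown leave open whether the larger step follows the arrival of the ethylsulfonyl group or the departure of the pyrazole ring, a question that a propanoyl group on the same nitrogen of each core could help separate. They also leave open whether a methylsulfonyl group or a longer alkylsulfonyl chain would show the same gap between the two cores.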